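A few compounds are considered here, and "the series" means these few. Any claim that something is new, unique, unknown or untested is made for them only; others in the source may bear on it.

Compound 1, whose structure is `COc1cc(NC(C)CCCNC(=O)Nc2ccc(Cl)c(C(F)(F)F)c2)c2ncccc2c1`, is followed here through a single structural change. In a functional assay on MCF7 cells (Homo sapiens) for inhibition, read by MTT assay, with a stated time of 4 days (on this read-out lower numbers stand for stronger inhibition and higher numbers for weaker inhibition), compound 1 gives 4000 nM. Among the three measured compounds this places it second highest. The nearest number belongs to compound 2, `O=C(NC(c1ccccc1)c1ccc(Cl)cc1)n1nnc2ccccc21`, which in this assay gives 42000 nM, a higher number that lies beyond the scatter. The furthest belongs to compound 3, `COc1cc(NC(C)CCCNC(=O)NNC(=O)NCCCC(C)Nc2cc(OC)cc3cccnc23)c2ncccc2c1`, which in this assay gives 200 nM, a lower number that also lies beyond the scatter. No pair among these three differs in only one place, so the numbers can only be set side by side.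

The compound not yet measured is compound 4, `COc1cc(NC(C)CCCNC(=O)NNC(=O)NC(CO)(CO)CO)c2ncccc2c1`. Its difference from compound 1 is ((2-hydroxy-1,1-bis(hydroxymethyl)ethyl)carbamoyl)amino in place of 4-chloro-3-(trifluoromethyl)phenyl on an amide-type nitrogen. For the measured compounds named here, no measured pair shows the consequence of this kind of swap, so the expectation rests on the numbers above alone. With the aromatic group gone and a group rich in hydrogen-bond donors in its place, the step from compound 1 to compound 4 is expected to run towards weaker inhibition, by an amount beyond the scatter, namely a 3.8-fold higher number from compound 1 to compound 4 (0.57 log units; beyond the scatter). For compound 4 in this assay the estimate is therefore 15000 nM, with a range from 3000 nM to 60000 nM.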

Compound 4, half-maximal inhibitory concentration: 28000 nM
Beside the measured number, compound 4's estimate is 1.9-fold (0.27 log units) below it; measured number inside the range.
By their numbers in this assay, from the lowest: compound 3; then compound 1; then compounds 4 and 2 (each within the scatter of the next).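

In this assay, for the compounds shown here, the swap of 4-chloro-3-(trifluoromethyl)phenyl for ((2-hydroxy-1,1-bis(hydroxymethyl)ethyl)carbamoyl)amino on the amide-type nitrogen gives a 7.0-fold higher number from compound 1 to compound 4 (0.85 log units; beyond the scatter) and so puts the first measured size on a change at this position, which no earlier pair could do. The step runs towards weaker inhibition, and it comes from a swap that keeps the count of heavy atoms but exchanges an aromatic ring of carbon only for an open group with no ring that carries hydrogen-bond donors and acceptors. Nothing available connects this shift to any measured property of either group.

The compounds shown leave open whether the step follows from the loss of the aromatic ring or from the arrival of the new group, as both change together in this single pair. A benzyl group, a carboxylic acid or a simple amine on the same amide-type nitrogen, or a phenyl ring lacking the chlorine or the trifluoromethyl group, would be needed to separate these contributions.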